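Nitro for chloro on a naphthol pyrazole series

The compounds below may be only part of what the source reports. "The series", "measured", "known", "first", "only" and "open" are said of these compounds alone.

Three compounds share a core and differ in their substituents. Compound 1 `O=[N+]([O-])c1cccc(-c2nn(-c3ccccc3)cc2C(Nc2nc3ccccc3s2)c2c(O)ccc3ccccc23)c1` and compound 2 `Oc1ccc2ccccc2c1C(Nc1nc2ccccc2s1)c1cn(-c2ccccc2)nc1-c1cccc(Cl)c1` carry a phenyl-substituted pyrazole; in a functional assay on MCF7 cells (Homo sapiens) for antiproliferative activity, read by MTT assay, with a stated time of 48 h (on this read-out higher numbers stand for weaker inhibition and lower numbers for stronger inhibition), compound 1 gives 43900 nM and compound 2 gives 20700 nM. The change between them, (nitro in place of chloro on an aromatic carbon), made a step of a 2.1-fold higher number from compound 2 to compound 1 (0.33 log units; beyond the scatter). Compound 3 `COc1ccc2nc(NC(c3cn(-c4ccccc4)nc3-c3ccc(Cl)cc3)c3c(O)ccc4ccccc34)sc2c1` has a different core; how its core differs from that of compound 2 is not broken down here. In this assay compound 3 gives 23700 nM. Compound 4 `COc1ccc2nc(NC(c3cn(-c4ccccc4)nc3-c3ccc([N+](=O)[O-])cc3)c3c(O)ccc4ccccc34)sc2c1` differs from compound 3 by nitro in place of chloro on an aromatic carbon, the same kind of change, placed para to a large group rather than meta to a large group. Compound 4 is expected to give 50000 nM (range 20000 nM to 120000 nM) in this assay. This estimate rests on the step of a 2.1-fold higher number from compound 2 to compound 1 (0.33 log units; beyond the scatter), so a step of a 2.1-fold higher number from compound 3 to compound 4 (0.32 log units; beyond the scatter) is expected.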

Compound 4, half-maximal inhibitory concentration: 13300 nM
Compound 4: the middle estimate sits 3.8-fold (0.58 log units) above what was measured; the measured number lies below the stated range.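

In this assay, nitro in place of chloro on the core of compound 3 gave a 1.8-fold lower number from compound 3 to compound 4 (0.25 log units; within the scatter), a step that stays within the scatter and so does not separate the two compounds. The change therefore did not carry over from one core to the other with the size and direction seen first: the same change on two cores in this assay, a 2.1-fold higher number (0.33 log units; beyond the scatter) from compound 2 to compound 1 and a 1.8-fold lower number (0.25 log units; within the scatter) from compound 3 to compound 4, 3.8-fold (0.58 log units) apart, beyond the scatter of two such steps This shows that the earlier step cannot be transferred as a fixed increment within this series, but it does not show whether the core or the position of the change accounts for the gap, as the two pairs differ in both.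

As far as these compounds go, it remains open whether moving the nitro group on a single core would reproduce this gap. Also open, from the compounds shown here alone, is how an amine or a carboxylic acid on the same aromatic carbon would compare with chloro and nitro.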